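This account rests on a few compounds, and the source may have more. Where it says the series, first, only, none or still open, it means among the compounds named here.

Measured in a functional assay on G-361 cells (Homo sapiens) for inhibition, with a stated time of 72 h; a higher number here means a weaker inhibitor, a lower number a stronger inhibitor:
- compound 1 `COc1ccccc1-c1ccc(CNc2nc(NC3CCC(N)CC3)nc3c2ncn3C2CCCC2)cc1`: 545 nM
- compound 2 `NC1CCC(Nc2nc(NCc3ccc(-c4ccco4)cc3)c3ncn(C4CCCC4)c3n2)CC1`: 164 nM
- compound 3 `CC(C)(O)CNc1nc(NCc2ccc(-c3ccco3)cc2)c2ncn(C3CCCC3)c2n1`: 17400 nM

Of these three, compound 2 has the lowest number at 164 nM, and the other two lie beyond the scatter from it. The unmeasured compound 4 `NC1CCC(Nc2nc(NCc3ccc(-c4ccccc4)nc3)c3ncn(C4CCCC4)c3n2)CC1` shares its core and its 4-aminocyclohexyl group with compound 2. It differs in one place, on a saturated chain carbon bound to a nitrogen on an aromatic ring, with 6-phenylpyridin-3-yl in place of 4-(furan-2-yl)phenyl (6-phenylpyridin-3-yl in place of 4-(furan-2-yl)phenyl on a saturated chain carbon bound to a nitrogen on an aromatic ring).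

Two measured steps can be weighed against this change. The closer one is a 3.3-fold lower number from compound 1 to compound 2 (0.52 log units; beyond the scatter), a modest step in which furan-2-yl replaced 2-methoxyphenyl. Like compound 4, compound 1 carries no furan-2-yl, so this step hints that losing that group could raise the number somewhat. The other step, a 110-fold higher number from compound 2 to compound 3 (2.03 log units; beyond the scatter), is large, but it replaced the 4-aminocyclohexyl group, which compound 4 retains, so it offers no guide here.

A small rise is therefore expected, not clearly beyond the scatter. The expected change is a 1.7-fold higher number from compound 2 to compound 4 (0.23 log units; within the scatter). For compound 4 the estimated value is 280 nM, with an expected range of 80 nM to 900 nM.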

Compound 4, half-maximal inhibitory concentration: 895 nM
Compound 4: the middle estimate sits 3.2-fold (0.50 log units) below what was measured; measured number inside the range.
By their numbers in this assay, from the lowest: compound 2; then compounds 1 and 4 (each within the scatter of the next); then compound 3.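

The result shows that this position on the saturated chain carbon is sensitive to the aryl group with the 4-aminocyclohexyl group held constant: a 5.5-fold higher number from compound 2 to compound 4 (0.74 log units; beyond the scatter) in this assay, a modest step that lies beyond the scatter but remains far smaller than a 110-fold higher number from compound 2 to compound 3 (2.03 log units; beyond the scatter). It also adds a second compound without furan-2-yl at this place, and compound 1 and compound 4 stand within the scatter of each other, so among these three compounds the one carrying 4-(furan-2-yl)phenyl, compound 2, has the lowest number. Nothing given here accounts for the size of this step.

The change alters two things at once, since the six-membered ring of carbon only that bears the furan-2-yl gives way to one with a hetero atom and the furan-2-yl gives way to a phenyl, so the share of each in the step remains unresolved. Going by these compounds, a 6-(furan-2-yl)pyridin-3-yl group or a 4-phenylphenyl group at this place would separate the two, and whether either would keep the number of compound 2 remains open.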